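Fluoro in place of hydrogen: what to expect for compound 4

A few compounds are considered here, and "the series" means these few. Any claim that something is new, unique, unknown or untested is made for them only; others in the source may bear on it.

Three analogues of the shared core have been measured. In a functional assay on MGC-803 cells (Homo sapiens) for inhibition, read by MTT assay, with a stated time of 48 h (on this read-out higher numbers stand for weaker inhibition and lower numbers for stronger inhibition), compound 1 `COc1ccc(CNc2cc(OC)c(OC)c(OC)c2)cc1Br` gives 29400 nM, compound 2 `COC(=O)c1cc(CNc2cc(OC)c(OC)c(OC)c2)ccc1OC` gives 49600 nM, and compound 3 `COc1ccc(CNc2cc(OC)c(OC)c(OC)c2)cc1` gives 11400 nM. Compound 3 stands lowest of the three: the number drops by a 2.6-fold lower number from compound 1 to compound 3 (0.41 log units; beyond the scatter) and by a 4.4-fold lower number from compound 2 to compound 3 (0.64 log units; beyond the scatter), both beyond the scatter. The gap a 1.7-fold higher number from compound 1 to compound 2 (0.23 log units; within the scatter) lies within the scatter, so compound 1 and compound 2 cannot be ordered.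

Compound 4 `COc1ccc(CNc2cc(OC)c(OC)c(OC)c2)cc1F` is the next analogue, differing from compound 3 by fluoro in place of hydrogen on an aromatic carbon. The two measured steps that bear on this change run in the opposite direction: removing a group from the same aromatic carbon lowered the number, by a 2.6-fold lower number from compound 1 to compound 3 (0.41 log units; beyond the scatter) for bromo and by a 4.4-fold lower number from compound 2 to compound 3 (0.64 log units; beyond the scatter) for methoxycarbonyl. Placing a group back on that carbon is therefore expected to raise the number, and fluoro, with its 1 heavy atom, is expected to give a smaller rise than either bromo or methoxycarbonyl, plausibly close to the edge of the scatter. The expected step in this assay is a 1.6-fold higher number from compound 3 to compound 4 (0.20 log units; within the scatter), upward. Compound 4 is thus estimated at 18000 nM, with a range from 9000 nM to 40000 nM.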

Compound 4, half-maximal inhibitory concentration: 39700 nM
Compound 4: the middle estimate sits 2.2-fold (0.34 log units) below what was measured; the range from low to high includes it.
By their numbers in this assay, from the lowest: compound 3; then compounds 1, 4 and 2 (each within the scatter of the next).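

In this assay, fluoro is enough to produce the whole rise at this aromatic carbon ortho to a methoxy group: the step is a 3.5-fold higher number from compound 3 to compound 4 (0.54 log units; beyond the scatter) even though only 1 heavy atom enters. Among the substituted compounds, the number does not follow the size of the group, with a 1.4-fold higher number from compound 1 to compound 4 (0.13 log units; within the scatter) for the exchange of bromo and a 1.2-fold lower number from compound 2 to compound 4 (0.10 log units; within the scatter) for the exchange of methoxycarbonyl. Fluoro, bromo and methoxycarbonyl therefore cannot be ordered here, and in these four compounds the clear difference lies between hydrogen and any of the three groups, with no listed compound going against that split. No measurement shown gives a reason for this behaviour.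

Still open, on these data alone, is whether an amine, a hydroxy group or a carboxylic acid on this aromatic carbon would fall with compound 1, compound 2 and compound 4 or would stay close to compound 3. Also open, as far as these compounds go, is whether fluoro on another carbon of this ring would raise the number in the same way, or whether the step belongs to this place alone.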